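Adding a Benzyloxycarbonyl Group to the Ring Amine of Compound 1

This account rests on a few compounds, and the source may have more. Where it says the series, first, only, none or still open, it means among the compounds named here.

Compound 1, `Cc1cc(C)c(S(=O)(=O)N[C@@H](CNC(=O)C2=NO[C@]3(CN[C@H](CNc4ncc[nH]4)C3)C2)C(=O)O)c(C)c1`, gives 230 nM.
Compound 2, `O=C(NC[C@@H](C(=O)O)S(=O)(=O)c1c(Cl)cccc1Cl)C1=NOC2(CCC(CNc3ncc[nH]3)CC2)C1`, gives 3000 nM.
Compound 3, `Cc1cccc(C)c1S(=O)(=O)[C@@H](CNC(=O)C1=NOC2(CCC(CNc3ncc[nH]3)CC2)C1)C(=O)O`, gives 1800 nM.

These three compounds were tested in a functional assay for antagonist activity at integrin alpha-5/beta-1 (Homo sapiens), read by ELISA; on this read-out higher numbers stand for weaker inhibition and lower numbers for stronger inhibition. Compound 1 stands lowest of the three, so it is the strongest inhibitor here: compound 3 sits well above it, and compound 2 further still, both gaps beyond the usual scatter. For the measured compounds named here, the only step between compounds that differ in one place is a 1.7-fold lower number from compound 2 to compound 3 (0.22 log units; within the scatter), a change on the aryl group attached to the sulfonyl sulfur; that step lies within the scatter and tells nothing about the ring amine nitrogen.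

Compound 4, `Cc1cc(C)c(S(=O)(=O)N[C@@H](CNC(=O)C2=NO[C@]3(C2)C[C@@H](CNc2ncc[nH]2)N(C(=O)OCc2ccccc2)C3)C(=O)O)c(C)c1`, differs from compound 1 by benzyloxycarbonyl in place of hydrogen on an amine nitrogen in a ring. Going by the values given here, no measured pair varies this nitrogen, so there is no guide for the size or direction of the step. The expectation is therefore taken as a cautious move away from compound 1, a 2.6-fold higher number from compound 1 to compound 4 (0.42 log units; beyond the scatter), with a wide range. Compound 4 is estimated at 600 nM, between 150 nM and 3000 nM.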

Compound 4, half-maximal inhibitory concentration: 18 nM
Estimate against measurement, compound 4: 33-fold (1.52 log units) above; measured number outside the range, below it.
By their numbers in this assay, from the lowest: compound 4; then compound 1; then compounds 3 and 2 (each within the scatter of the next).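

In this assay, the ring amine nitrogen proves able to carry a large group without loss of inhibition: a 13-fold lower number from compound 1 to compound 4 (1.11 log units; beyond the scatter) shows that benzyloxycarbonyl in place of hydrogen goes with stronger inhibition. For the compounds shown here, no earlier pair varied this nitrogen, and this single change now marks it as a place where the number can shift well beyond the scatter. Nothing available explains why the number falls with this change.

The compounds shown hold no ring nitrogen bearing an acetyl, a methyl or a benzyl group, so it stays open whether the step goes with the aromatic ring, the carbonyl or the whole benzyloxycarbonyl. On these data alone, it is also open whether the same step would appear with a different aryl group on the sulfonyl sulfur.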